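This account rests on a few compounds, and the source may have more. Where it says the series, first, only, none or still open, it means among the compounds named here.

Results so far in a functional assay on HL-60 cells (Homo sapiens) for inhibition, read by MTT assay, with a stated time of 48 h, tested at 10 uM; a lower number here means less inhibition of growth, a higher number more inhibition of growth at the concentration tested:
- compound 1 `Cc1cc(=O)c2c(O)cc(OCc3ccccc3)c([C@H]3CCN(C)C[C@H]3O)c2o1` gives 24%
- compound 2 `Cc1oc2c([C@H]3CCN(C)C[C@H]3O)c(O)cc(O)c2c(=O)c1C(O)c1cc(F)cc(F)c1` gives 30%
- compound 3 `CN1CC[C@H](c2c(O)cc(O)c3c(=O)cc(/C=C/c4ccc(Cl)cc4)oc23)[C@H](O)C1` gives 58%

Each number shows how much cell growth was held back at a single test concentration, so a higher number means a stronger effect in this test. Compound 3 stands highest of the three, and compound 1 and compound 2 both lie below it by gaps beyond the scatter. These two compounds differ from compound 3 in more than one place, so their gaps cannot be pinned on any single group.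

The next compound, compound 4 `CN1CC[C@H](c2c(O)cc(O)c3c(=O)cc(/C=C/c4c(F)c(F)c(F)c(F)c4F)oc23)[C@H](O)C1`, differs from compound 3 in one place only. It has 2,3,4,5,6-pentafluorophenyl in place of 4-chlorophenyl on a double-bonded chain carbon bound to a double-bonded chain carbon. Among the compounds with values here, compound 3 at 58% is the only measured compound with an aromatic ring on such a chain, which makes it the best available guide. Within the data shown here, no measured pair shows what exchanging that ring does, so the range must stay wide.

The expected change in this assay is a number 6 percentage points lower from compound 3 to compound 4 (within the scatter) and is estimated to lean slightly downward, without going beyond the scatter. The estimated value for compound 4 is 52% in a range from 30% to 74% for the measurement still to come.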

Compound 4, percent growth inhibition at one concentration: 80%
Compound 4: the middle estimate sits 28 percentage points below what was measured, outside the stated range (above it).
By their numbers in this assay, from the lowest: compounds 1 and 2 (each within the scatter of the next); then compound 3; then compound 4.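

In this assay, within the data shown here, the exchange of 4-chlorophenyl for 2,3,4,5,6-pentafluorophenyl on a double-bonded chain carbon gives a number 22 percentage points higher from compound 3 to compound 4 (beyond the scatter), the first single-place step in this set, and it shows that growth inhibition responds to what the aromatic ring at this place carries. Both rings are six-membered aromatic rings of carbon only, with no hydrogen-bond donors or acceptors and no net charge, so the step comes from a change in the ring's attached atoms, with chlorine leaving and fluorine entering, and not from any change in those counts. Nothing measured here explains why the number rises.

This one step cannot separate the loss of the chlorine from the gain of the fluorines, and it rests on a single test concentration, so it gives no full dose-response picture. The compounds shown leave open how an unsubstituted phenyl, a 4-fluorophenyl or a 4-aminophenyl at the same place would compare, and whether a ring carrying a carboxylic acid would hold this level of growth inhibition.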